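Ethoxy on the chain carbon of compound 2

The source may report more compounds than this note shows. Statements on the series, on what has been measured and on what is new or still open speak of the compounds shown alone.

In a functional assay on the whole organism (arterial blood) with Rattus norvegicus as the target (a lower number here means that less compound is needed, a higher number that more compound is needed for the effect), compound 1 `Cc1nc2cnccc2n1CC1CCN(C(=O)CCc2ccccc2)CC1` is reported only as a limit, > 5 mg/kg.

Compound 2 `Cc1nc2cnccc2n1CC1CCN(C(=O)N[C@H](C)c2ccccc2)CC1` gives a true number, 0.017 mg/kg. Compound 3 `Cc1nc2cnccc2n1CC1CCN(C(=O)NC2(c3ccccc3)CC2)CC1` gives 0.021 mg/kg. These two share the low end of the numbers shown and lie within the scatter of each other. The large step of an at least 290-fold lower number from compound 1 to compound 2 (2.46 log units; beyond the scatter) replaces phenethyl on the carbonyl carbon with (1-phenylethyl)amino, and this urea-type link is kept in every compound that follows.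

Compound 4 `CCOC[C@@H](NC(=O)N1CCC(Cn2c(C)nc3cnccc32)CC1)c1ccccc1` has not yet been measured in this assay. It departs from compound 2 by ethoxy in place of hydrogen on a saturated chain carbon, two bonds along the chain from an amide-type nitrogen and an aromatic carbon; cut one bond further out, this reads as methyl to ethoxymethyl. The closest measured evidence is the step of a 1.2-fold higher number from compound 2 to compound 3 (0.09 log units; within the scatter), which replaces 1-phenylethyl with 1-phenylcyclopropyl and stays within the scatter. The large first step lies elsewhere in the molecule and says little about this change. Within the data shown here, no measured compound carries an ethoxy group, so the evidence is indirect.

A small change is expected, a 1.8-fold higher number from compound 2 to compound 4 (0.25 log units; within the scatter), leaning slightly towards a higher number. For compound 4 the estimated value is 0.03 mg/kg, with an expected range from 0.008 mg/kg to 0.12 mg/kg.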

Compound 4, dose for 50% inhibition: 0.019 mg/kg
The estimate for compound 4 lay 1.6-fold (0.20 log units) above the measured number, within the range that was stated.
By their numbers in this assay, from the lowest: compounds 2, 4 and 3 (each within the scatter of the next). At a limit, above all of these: compound 1.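

In this assay, the step of a 1.1-fold higher number from compound 2 to compound 4 (0.05 log units; within the scatter) shows that this saturated chain carbon, two bonds along the chain from an amide-type nitrogen and an aromatic carbon, can carry ethoxy without a change in the number that can be told from the scatter. The earlier compounds had shown only that 1-phenylcyclopropyl could stand in place of 1-phenylethyl, and neither of those groups has an oxygen atom or reaches further out than the ring; methyl to ethoxymethyl adds three heavy atoms, among them a hydrogen-bond acceptor, and the number still stays level with that of compound 2. Nothing among the data shown gives a measured property that would account for this result.

The compounds shown leave open whether this carbon would accept other groups in the same way, such as a dimethylaminomethyl group, a carboxylic acid or a longer chain like butoxymethyl. Among these compounds, they also leave open how far ethoxy itself could be extended before the number in this assay moves beyond the scatter, since a single ether is the only such group on this carbon.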